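A Thioether Aryl Swap in a Cell Growth Assay

The source may hold more compounds than are shown below. What is called first, only, known or untested is meant among the compounds shown, and "the series" means these compounds.

Going by the values given here, compound 2, `Nc1cc(N)c2nc(-c3ccccc3)c(Sc3ccc(Cl)c(Cl)c3)nc2c1`, is the only compound here with a measured number: in a functional assay on M14 cells (Homo sapiens) for inhibition, read by sulforhodamine B assay, with a stated time of 48 h (on this read-out lower numbers stand for stronger inhibition of growth and higher numbers for weaker inhibition of growth), compound 2 gives 32400 nM. Compound 1, `COc1ccc(Sc2nc3cc(N)cc(N)c3nc2-c2ccccc2)cc1`, carries a different ring on the sulfur. In this assay compound 1 gives < 100000 nM, which is a limit of the assay rather than a number. The step that the limit leaves unreadable from compound 1 to compound 2 therefore has no readable size. The unmeasured compound 3, `Nc1cc(N)c2nc(-c3ccccc3)c(Sc3ccc(F)cc3)nc2c1`, differs from compound 2 by 4-fluorophenyl in place of 3,4-dichlorophenyl on a sulfur. Among the compounds with values here, no measured step covers this exact change, and the one related step, a step that the limit leaves unreadable from compound 1 to compound 2, stays unreadable because of the limit of < 100000 nM in this assay, at which 1 of the 2 values shown sits. Resting only on the value of compound 2, 32400 nM, the expected step is a 1.2-fold higher number from compound 2 to compound 3 (0.09 log units; within the scatter), a change within the scatter. Compound 3 is estimated at 40000 nM, with a range from 10000 nM to 160000 nM.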

Compound 3, concentration for 50% growth inhibition: 15800 nM
Beside the measured number, compound 3's estimate is 2.5-fold (0.40 log units) above it; measured number inside the range.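

Going by these compounds alone, the change from 3,4-dichlorophenyl to 4-fluorophenyl on the sulfur gives a 2.1-fold lower number from compound 2 to compound 3 (0.31 log units; beyond the scatter), the first step at this position in this assay whose size can be read. It shows that the ring on the sulfur can change the measured growth inhibition, and that between these two compounds the ring with a single fluorine, not the one with two chlorines, gives the lower number and so the stronger inhibition. The steps from compound 1 cannot be read, because compound 1 carries a limit of the assay and not a number: the limit of < 100000 nM in this assay, at which 1 of the 3 values shown sits.

One step cannot separate the effect of adding the fluorine from that of removing the chlorines. Also open, as far as these compounds go, is how a ring carrying an amine or a carboxylic acid on the sulfur would read.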